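A few compounds are considered here, and "the series" means these few. Any claim that something is new, unique, unknown or untested is made for them only; others in the source may bear on it.

Compound 1 `CNC(=O)c1cc(Oc2ccc(C(=O)/C=C/c3ccco3)cc2)ccn1`: "not determined" (no result reported)
Compound 2 `CNC(=O)c1cc(Oc2ccc(C(=O)/C=C/c3ccc(OC)c(OC)c3OC)cc2)ccn1`: 2910 nM
Compound 3 `CNC(=O)c1cc(Oc2ccc(C(=O)/C=C/c3ccc([N+](=O)[O-])cc3)cc2)ccn1`: "not determined" (no result reported)

In a functional assay on MCF7 cells (Homo sapiens) for cytotoxicity, read by MTT assay, with a stated time of 72 h (a lower number here means a stronger inhibitor, a higher number a weaker inhibitor), compound 3 stands at "not determined" (no result reported), so it offers no number to start from. Compound 1 is in the same position, at "not determined" (no result reported). Only compound 2 has a number, 2910 nM.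

Compound 4 `CNC(=O)c1cc(Oc2ccc(C(=O)/C=C/c3ccc(F)cc3)cc2)ccn1` has not yet been measured. The change fluoro in place of nitro on an aromatic carbon puts fluoro in place of nitro on an aromatic carbon, para to a large group.

With no number for compound 3, the size and direction of this step cannot be read from the data. Among the compounds with values here, the only anchor is compound 2 at 2910 nM, so a value for compound 4 in that region is expected, perhaps somewhat weaker. The estimate for compound 4 is 5000 nM, with an expected range of 1500 nM to 20000 nM.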

Compound 4, half-maximal inhibitory concentration: 28500 nM
The estimate for compound 4 lay 5.7-fold (0.76 log units) below the measured number; measured number above the stated range.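

In this assay, within the data shown here, compound 3 stands at "not determined" (no result reported) so no step to compound 4 can be read. As far as these compounds go, what fluoro in place of nitro does to potency therefore stays open. Nothing shown here explains the value of compound 4.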